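Trimming the amide substituent and the inhibition of dipeptidyl peptidase 4

The compounds below may be only part of what the source reports. "The series", "measured", "known", "first", "only" and "open" are said of these compounds alone.

Compound 1, `C[C@@H]1N[C@H](C(=O)N2CCC[C@H]2C#N)C[C@@H]1C(=O)N1CCC1`: 88%
Compound 3, `CCN(C)C(=O)[C@H]1C[C@@H](C(=O)N2CCC[C@H]2C#N)N[C@H]1C`: 79%
Compound 2, `CCN(CC)C(=O)[C@@H]1CN[C@H](C(=O)N2CCC[C@H]2C#N)C1`: "not determined" (no result reported)

Three compounds have been run in an assay on the whole organism (plasma, strain Sprague-Dawley) for inhibition of Dipeptidyl peptidase 4 (Rattus norvegicus), with a stated time of 10 h, at a dose of 1 mg/kg by the oral route (on this read-out lower numbers stand for less inhibition and higher numbers for more inhibition at the one dose given (going by the name of the read-out)), and a fourth, compound 4 with the structure `N#C[C@@H]1CCCN1C(=O)[C@@H]1C[C@H](C(N)=O)CN1`, has not yet been tested. In this assay, among the compounds with values here, compound 1 gives 88% and compound 3 gives 79%; the only one-place step among the measured compounds is a number 9 percentage points lower from compound 1 to compound 3 (within the scatter), which swaps one amide substituent for another on a carbonyl carbon. Compound 2 stands nowhere on the numbers, since for compound 2 the result in this assay is "not determined" (no result reported).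

Compound 4 differs from compound 2 by amino in place of diethylamino on a carbonyl carbon, read one bond further out as diethylcarbamoyl to carbamoyl. Within the data shown here, the one measured step that bears on this kind of change is the amide swap from compound 1 to compound 3, which stayed within the scatter, but that swap kept a fully substituted amide, whereas here the diethylamino group is cut back to amino. With no number for compound 2, the estimate rests on the other two compounds. Because compound 1 gives 88% and compound 3 gives 79%, compound 4 is expected to land somewhat lower but still in that region. The estimate for compound 4 is 72%, with a range from 50% to 90%.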

Compound 4, a percentage reported as inhibition, in the whole organism at one dose (the size of the read-out at that dose, not a potency): 20%
The estimate for compound 4 lay 52 percentage points above the measured number; measured number below the stated range.
By their numbers in this assay, from the lowest: compound 4; then compounds 3 and 1 (each within the scatter of the next).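

In this assay, within the data shown here, compound 4 gives 20%, while compound 2, which differs from it in one place, stands as "not determined" (no result reported), so no step between the two can be read. The compounds shown leave open what amino in place of diethylamino does to this read-out. No evidence at hand bears on the result.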